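Fluoro to Hydrogen on the Aryl Ring of Compound 3

A few compounds are considered here, and "the series" means these few. Any claim that something is new, unique, unknown or untested is made for them only; others in the source may bear on it.

Measured so far:
compound 1 `Nc1ccccc1NC(=O)c1ccc(CSC(=S)N2CCN(c3ccc(Cl)cc3)CC2)cc1` — 29%
compound 2 `Nc1ccccc1NC(=O)c1ccc(CSC(=S)N2CCN(C(c3ccccc3)c3ccccc3)CC2)cc1` — 8.4%
compound 3 `Nc1ccccc1NC(=O)c1ccc(CSC(=S)N2CCN(c3ccccc3F)CC2)cc1` — 79.5%

In a functional assay on A-375 cells (Homo sapiens) for antiproliferative activity, read by CCK-8 assay, with a stated time of 72 h, tested at 8 uM (on this read-out higher numbers stand for a stronger effect at the one concentration tested and lower numbers for a weaker effect), compound 3 stands highest of the three measured compounds, beyond the scatter above both compound 1 and compound 2. Compound 4 `Nc1ccccc1NC(=O)c1ccc(CSC(=S)N2CCN(c3ccccc3)CC2)cc1` differs from compound 3 by hydrogen in place of fluoro on an aromatic carbon, that is, 2-fluorophenyl becomes phenyl. For the measured compounds named here, the only measured step touching this part of the molecule is a number 50.5 percentage points higher from compound 1 to compound 3 (beyond the scatter), which shows that changing the group on the amine nitrogen in the ring can move the read-out a long way; compound 2, with yet another group there, shows a low value. Going by the values given here, no measured step removes a fluoro alone, so the direction is uncertain, and a moderate loss is expected. Compound 4 is estimated at 55%, between 20% and 85%. This expectation means a step of a number 24.5 percentage points lower from compound 3 to compound 4 (beyond the scatter).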

Compound 4, a percentage reported as inhibition, at one concentration (the size of the read-out at that concentration, not a potency): 88.6%
Compound 4: the middle estimate sits 33.6 percentage points below what was measured; the whole stated range lies below it.
By their numbers in this assay, from the lowest: compound 2; then compound 1; then compounds 3 and 4 (each within the scatter of the next).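

Losing the fluoro makes no visible difference in this assay here: the change gives a number 9.1 percentage points higher from compound 3 to compound 4 (within the scatter) and so the 2-fluorophenyl and phenyl groups cannot be told apart. Removing the chloro is another matter, with a number 59.6 percentage points higher from compound 1 to compound 4 (beyond the scatter) showing that a phenyl group with no added substituent is enough for a high read-out, while the 4-chlorophenyl group sits far lower. Nothing available explains either step.

Going by these compounds, it remains open whether a methyl or a methoxy group on that same aromatic carbon would match the fluoro, or would instead pull the read-out down as the chloro of compound 1 does at its own place.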